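A few compounds are considered here, and "the series" means these few. Any claim that something is new, unique, unknown or untested is made for them only; others in the source may bear on it.

In a functional assay on HCT-116 cells (Homo sapiens) for antiproliferative activity, read by MTT assay, with a stated time of 72 h (a lower number here means a stronger inhibitor, a higher number a weaker inhibitor), compound 1 `CC(C)(C)NC(=O)CCc1cccc2c1B(O)OC2` gives > 100000 nM, which is a limit of the assay and not a number. Compound 3 `O=C(CCc1cccc2c1B(O)OC2)Nc1ccc(F)cc1` gives 650 nM, within the scatter of compound 2 `O=C(CCc1cccc2c1B(O)OC2)Nc1ccccc1` at 350 nM. Compound 4 `O=C(CCc1cccc2c1B(O)OC2)Nc1ccc(Cl)cc1` keeps everything in compound 3 except for chloro in place of fluoro on an aromatic carbon. The large steps, an at least 280-fold lower number from compound 1 to compound 2 (2.45 log units; beyond the scatter) and an at least 150-fold lower number from compound 1 to compound 3 (2.18 log units; beyond the scatter), replace the tert-butyl on the amide-type nitrogen and say little about this change. The closest guide is a 1.9-fold higher number from compound 2 to compound 3 (0.27 log units; within the scatter), at the same aromatic carbon, so no step beyond the scatter is expected in this assay. The expected change is a 1.1-fold lower number from compound 3 to compound 4 (0.03 log units; within the scatter). Compound 4 is estimated at 600 nM, with an expected range of 200 nM to 1800 nM.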

Compound 4, half-maximal inhibitory concentration: 12000 nM
Compound 4: middle estimate off by 20-fold (1.30 log units), on the low side; measured number above the stated range.
By their numbers in this assay, from the lowest: compounds 2 and 3 (each within the scatter of the next); then compound 4. At a limit, above all of these: compound 1.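

In this assay this aromatic carbon, para to a large group, proves sensitive to which halogen it carries (an 18-fold higher number from compound 3 to compound 4 (1.27 log units; beyond the scatter)), although compounds 2 and 3 stand within the scatter of each other. Chloro in place of hydrogen brings a similarly large step (a 34-fold higher number from compound 2 to compound 4 (1.54 log units; beyond the scatter)), so among the three groups shown at this carbon, only chloro marks a clear loss. The step from the tert-butyl amide (an at least 8.3-fold lower number from compound 1 to compound 4 (0.92 log units; beyond the scatter)) is only a bound, since compound 1 stands at a limit and not a number: the limit of > 100000 nM in this assay, at which 1 of the 4 values shown sits. As far as these compounds go, what bromo, methyl or methoxy at this carbon would give stays open, as does whether chloro at another carbon of the ring would bring the same loss.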